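A few compounds are considered here, and "the series" means these few. Any claim that something is new, unique, unknown or untested is made for them only; others in the source may bear on it.

Compound 1 `N#CCn1nc(-c2ccc(OCc3ccccc3)cc2)oc1=O`: 60 nM. Compound 2 `N#CCCCn1nc(-c2ccc(OCc3ccccc3)cc2)oc1=O`: 410 nM.

In an assay for inhibition of Amine oxidase [flavin-containing] B (Rattus norvegicus) (a higher number here means a weaker inhibitor, a lower number a stronger inhibitor), compound 1 gives 60 nM, while compound 2 gives 410 nM, the highest of the two numbers shown. Compound 3 `CC(C#N)n1nc(-c2ccc(OCc3ccccc3)cc2)oc1=O` has not yet been measured. It differs from compound 2 by 1-cyanoethyl in place of 3-cyanopropyl on an aromatic nitrogen. Among the compounds with values here, the one measured step that bears on this change is a 6.8-fold higher number from compound 1 to compound 2 (0.83 log units; beyond the scatter), which lengthened the chain; compound 3 shortens it again. Compound 3 is therefore expected to give a lower number, roughly a 3.7-fold lower number from compound 2 to compound 3 (0.57 log units; beyond the scatter). The estimate for compound 3 is 110 nM, with a range from 40 nM to 300 nM.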

Compound 3, half-maximal inhibitory concentration: 48000 nM
The estimate for compound 3 lay 440-fold (2.64 log units) below the measured number; the measured number lies above the stated range.
By their numbers in this assay, from the lowest: compound 1; then compound 2; then compound 3.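

In this assay, the chain's length does not decide the outcome at this position: the methyl in place of hydrogen on the carbon bound to the aromatic nitrogen and the nitrile gives an 800-fold higher number from compound 1 to compound 3 (2.90 log units; beyond the scatter). The shorter 1-cyanoethyl group does not recover potency either, giving a 120-fold higher number from compound 2 to compound 3 (2.07 log units; beyond the scatter), a far larger step than the one from lengthening the chain. No available evidence explains this loss.

The compounds shown leave open whether a second methyl or an ethyl on that same carbon, or a methyl further along a longer chain, would weaken inhibition similarly.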